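The source may hold more compounds than are shown below. What is called first, only, known or untested is meant among the compounds shown, and "the series" means these compounds.

Measured in an assay for inhibition of inositol hexakisphosphate kinase 2 (Homo sapiens), read by colorimetric assay, coupled enzyme assay and malachite green, with a stated time of 120 min, in the presence of a further agent that is not named here; on this read-out higher numbers stand for weaker inhibition and lower numbers for stronger inhibition:
Compound 1 `Cc1cccc(-c2onc3ccc(/C=C/C(=O)O)cc23)c1` gives 290 nM.
Compound 2 `O=C(O)c1ccc2noc(-c3ccc(Oc4ncc(Cl)cc4Cl)cc3)c2c1` gives 650 nM.
Compound 3 `Cc1cccc(-c2onc3ccc(C(=O)O)cc23)c1` gives 150 nM.

Compound 3 stands at the lowest of the three numbers in this assay. Its nearest neighbour is compound 1; the step of a 1.9-fold lower number from compound 1 to compound 3 (0.29 log units; within the scatter) lies within the usual scatter, so these two compounds cannot be separated on the numbers shown. Compound 2 lies furthest from compound 3, and that gap is beyond the scatter.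

Compound 4 `O=C(O)c1ccc2noc(-c3cccc(Oc4ccccn4)c3)c2c1` arises from compound 3 by (pyridin-2-yl)oxy in place of methyl on an aromatic carbon. Among the compounds with values here, the only computed step among the measured compounds, a 1.9-fold lower number from compound 1 to compound 3 (0.29 log units; within the scatter), concerns the carboxy end of the core and not the place where compound 3 carries its methyl, so it does not bear directly on this change. Within the data shown here, compound 2 is the only measured compound that also carries a pyridinyloxy group, and in this assay compound 2 gives a higher number than compound 3; no single step separates the two, since they differ in more than one place. Compound 4 is therefore expected to give a somewhat higher number than compound 3, an expected step of a 2.0-fold higher number from compound 3 to compound 4 (0.30 log units; within the scatter) that may not exceed the scatter. The estimate for compound 4 in this assay is 300 nM, with a range from 100 nM to 900 nM.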

Compound 4, half-maximal inhibitory concentration: 690 nM
Compound 4: the middle estimate sits 2.3-fold (0.36 log units) below what was measured, within the range that was stated.
By their numbers in this assay, from the lowest: compounds 3 and 1 (each within the scatter of the next); then compounds 2 and 4 (each within the scatter of the next).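

In this assay, (pyridin-2-yl)oxy in place of methyl, on an aromatic carbon of the six-membered carbon ring and meta to a large group, brings a 4.6-fold higher number from compound 3 to compound 4 (0.66 log units; beyond the scatter). This is the first single change among the compounds shown that lies beyond the scatter, and the first to touch this position, so the place that holds the methyl of compound 3 is not indifferent to what stands on it, whereas the only earlier step, a 1.9-fold lower number from compound 1 to compound 3 (0.29 log units; within the scatter), concerned the carboxy end and could not be separated from the scatter. The change brings in an oxygen, a further aromatic ring with a nitrogen and more heavy atoms all at once, and nothing available explains the rise in the number.

The compounds shown leave open which of these parts carries the step, and a methoxy group, a phenoxy group or an amine at this same place would each bear on that question. They also leave open whether 2-carboxyethenyl in place of carboxy would give the same result with (pyridin-2-yl)oxy present as it does with methyl.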